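Shortening the Bromoalkyl Chain: From Compound 2 to Compound 4

The source may report more compounds than this note shows. Statements on the series, on what has been measured and on what is new or still open speak of the compounds shown alone.

Of the compounds shown here, three sharing one core have been tested in a functional assay on ECa-109 cells for inhibition, with ECa-109 cell line (Homo sapiens) as the target, read by MTT assay, with a stated time of 48 h; a lower number here means a stronger inhibitor, a higher number a weaker inhibitor. Compound 1 `CCN1CCN(C(=S)SCCCOc2ccc3c(=O)c(-c4ccc(OC)cc4)coc3c2)CC1` gives 36900 nM. Compound 2 `COc1ccc(-c2coc3cc(OCCCCCBr)ccc3c2=O)cc1` gives 59100 nM, the highest of the three numbers; compound 1 sits nearest to it, within the scatter, while compound 3 `COc1ccc(-c2coc3cc(OCCCSC(=S)N4CCN(C(=O)OC(C)(C)C)CC4)ccc3c2=O)cc1` gives 3540 nM, the furthest and beyond the scatter. Two measured steps describe the set: a 1.6-fold higher number from compound 1 to compound 2 (0.20 log units; within the scatter), and a 10-fold lower number from compound 1 to compound 3 (1.02 log units; beyond the scatter).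

Compound 4 `COc1ccc(-c2coc3cc(OCCBr)ccc3c2=O)cc1` has not yet been measured. Its change from compound 2 is bromo in place of 3-bromopropyl on a saturated chain carbon, two bonds along the chain from an oxygen on an aromatic ring: the bromine stays, but the chain between it and the aromatic oxygen becomes shorter. Neither measured step bears directly on this change. The step from compound 1 to compound 2 concerns what sits at the chain end, not chain length, and the step from compound 1 to compound 3 concerns a different part of the molecule. The end group therefore matters little here, and nothing shows how much the chain length counts.

With no guide beyond this, the step is expected to be a 1.0-fold higher number from compound 2 to compound 4 (0.01 log units; within the scatter), which would not go beyond the scatter. Compound 4 is estimated at 60000 nM, within an expected range of 20000 nM to 180000 nM.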

Compound 4, half-maximal inhibitory concentration: 55100 nM
Estimate against measurement, compound 4: 1.1-fold (0.04 log units) above; low and high end bracket the measured number.
By their numbers in this assay, from the lowest: compound 3; then compounds 1, 4 and 2 (each within the scatter of the next).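

In this assay, going by these compounds alone, the earlier compounds gave no reading on chain length, and this pair supplies the first one: replacing (5-bromopentyl)oxy with 2-bromoethoxy, while keeping the bromine at the chain end, gives a 1.1-fold lower number from compound 2 to compound 4 (0.03 log units; within the scatter). For these two bromine-ended compounds, then, removing this stretch of the chain produces no change that can be told apart from the ordinary variation between repeated measurements, so chain length at this position shows no measurable effect across the two lengths compared. Nothing available here explains why the number holds steady across this change.

Still open, on these data alone, is whether a longer chain than 5-bromopentyl, or a short chain ending in an amine or a carboxylic acid instead of bromine, would move the number beyond the scatter. Also open, as far as these compounds go, is whether chain length would count for as little if the chain carried the tert-butoxycarbonyl end group of compound 3, since the pair here speaks only for chains that end in bromine.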